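Phenyl for pyridin-2-yl on the arpromidine-type diaryl carbon

This account rests on a few compounds, and the source may have more. Where it says the series, first, only, none or still open, it means among the compounds named here.

Within the data shown here, compound 1 `N=C(NCCCc1c[nH]cn1)NCCC(c1ccc(F)cc1)c1ccccn1` is the most potent of the three measured members: in a functional assay on cardiac atrium for agonist activity at histamine H2 receptor (Cavia porcellus) (a lower number here means a less potent compound, a higher number a more potent compound, by a factor of ten per unit of this negative logarithm), compound 1 gives 8.01, while compound 2 `N=C(NCCCc1c[nH]cn1)NCCC(c1ccccn1)c1ccccc1F` gives 7.46 and compound 3 `N=C(NCCCc1c[nH]cn1)NCCC(c1ccccn1)c1ccccn1` gives 6.9. The steps are a number 0.55 log units lower from compound 1 to compound 2 (beyond the scatter), a number 1.11 log units lower from compound 1 to compound 3 (beyond the scatter) and a number 0.56 log units lower from compound 2 to compound 3 (beyond the scatter), so each exchange of a fluorophenyl for pyridin-2-yl on the saturated chain carbon lowered the number. Compound 4 `N=C(NCCCc1c[nH]cn1)NCCC(c1ccccc1)c1ccc(F)cc1` differs from compound 1 by phenyl in place of pyridin-2-yl on a saturated chain carbon bound to an aromatic carbon and a saturated chain carbon. Among the measured compounds shown here, no measured step covers this exact exchange; the nearest, compound 1 to compound 3 and compound 2 to compound 3, show pyridin-2-yl entering in place of a fluorophenyl and cost potency, but in compound 4 the pyridin-2-yl leaves while the 4-fluorophenyl stays, and no compound with two carbon-only rings has been measured. A modest loss is therefore expected, with wide uncertainty: compound 4 is estimated at 7.6 (range 6.9 to 8.2), an expected step of a number 0.41 log units lower from compound 1 to compound 4 (beyond the scatter).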

Compound 4, negative logarithm of the half-maximal effective concentration: 7.73
For compound 4 the middle estimate is 0.13 log units below the measured one; the measured number falls inside the stated range.
By their numbers in this assay, from the lowest: compound 3; then compounds 2, 4 and 1 (each within the scatter of the next, the first and the last beyond it).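

Phenyl in place of pyridin-2-yl on this saturated chain carbon gives a number 0.28 log units lower from compound 1 to compound 4 (within the scatter), so with 4-fluorophenyl kept, the ring nitrogen of pyridin-2-yl is not needed to hold the number in this assay. The earlier steps shown here showed only pyridin-2-yl entering in place of a fluorophenyl, as in a number 1.11 log units lower from compound 1 to compound 3 (beyond the scatter); the two rings on this carbon therefore do not tolerate exchange alike, since the 4-fluorophenyl exchange costs potency and the pyridin-2-yl exchange stays within the scatter. No data at hand explain this difference between the two rings.

From the compounds shown here alone, whether a pyridin-3-yl or cyclohexyl group could take the place of pyridin-2-yl on this carbon stays open. Also open, going by these compounds, is what the fluorine of 4-fluorophenyl contributes when the second ring is phenyl.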